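Cytotoxicity at the limit: chloro to methyl on the aryl ring

The source may report more compounds than this note shows. Statements on the series, on what has been measured and on what is new or still open speak of the compounds shown alone.

Compound 1 `CC(=O)C1=NN(c2ccccc2)/C(=C2\S/C(=N/c3nc(-c4c(C)n(C)n(-c5ccccc5)c4=O)cs3)N(c3ccccc3)C2=O)S1` gives > 20000 nM in an ADME assay on Huh/NeoET cells (Homo sapiens) for cytotoxicity (a higher number here means that more compound is tolerated, a lower number that less compound is tolerated), a limit of the assay.
Compound 2 `CC(=O)C1=NN(c2ccc(Cl)cc2)/C(=C2\S/C(=N/c3nc(-c4c(C)n(C)n(-c5ccccc5)c4=O)cs3)N(c3ccccc3)C2=O)S1` gives > 20000 nM in this assay, also a limit.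

Compound 2 stands at the limit only; no number is known for it. The step that the two limits leave unreadable from compound 1 to compound 2 is therefore unreadable. Compound 3 `CC(=O)C1=NN(c2ccc(C)cc2)/C(=C2\S/C(=N/c3nc(-c4c(C)n(C)n(-c5ccccc5)c4=O)cs3)N(c3ccccc3)C2=O)S1` differs from compound 2 by methyl in place of chloro on an aromatic carbon. Only that one unreadable step bears on this change, and both shown values sit at the limit (the limit of > 20000 nM in this assay, at which 2 of the 2 values shown sit). Compound 3 is therefore expected to sit at the limit as well, so the step that the limit leaves unreadable from compound 2 to compound 3 is estimated to be no more than the scatter. The estimate for compound 3 in this assay is 30000 nM, between 12000 nM and 80000 nM.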

Compound 3, half-maximal cytotoxic concentration: > 20000 nM
Compound 3: no number, only a limit; the forecaster's own chance of this, stated with the estimate: 80%; the middle value does not contradict the limit.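

Compound 3 also stands at a limit, so no step among compound 1, compound 2 and compound 3 can be read in this assay: the limit of > 20000 nM in this assay, at which 3 of the 3 values shown sit.

The compounds shown leave open where any of them would reach a half-maximal cytotoxic concentration, and whether chloro or methyl makes any difference there.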